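Swapping methyl for dimethylamino on the aniline ring

The source may report more compounds than this note shows. Statements on the series, on what has been measured and on what is new or still open speak of the compounds shown alone.

Measured so far:
- compound 1, `CN(C)c1cccc(Nc2nccc(-c3ccccn3)n2)c1`, 400 nM
- compound 2, `Cc1cccc(Nc2nccc(-c3ccccn3)n2)c1`, 700 nM
- compound 3, `Cc1ccccc1Nc1nccc(-c2ccncc2)n1`, 3900 nM

All three were tested in a functional assay for inhibition, with Homo sapiens as the target; a higher number here means a weaker inhibitor, a lower number a stronger inhibitor. Compound 1 and compound 2 share a core and differ in one place: dimethylamino in place of methyl on an aromatic carbon, a change that gave a 1.8-fold lower number from compound 2 to compound 1 (0.24 log units; within the scatter). Compound 3 has the same atoms as compound 2 joined differently; the difference between the two cores is not broken down here. In this assay compound 3 gives the highest number of the three, with compound 2 the nearest and compound 1 the furthest, both gaps beyond the scatter.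

Compound 4, `CN(C)c1ccccc1Nc1nccc(-c2ccncc2)n1`, has not yet been measured. It is related to compound 3 by dimethylamino in place of methyl on an aromatic carbon. This is the same kind of change that turned compound 2 into compound 1, but not the same: there the new group sat meta to a large group, here it sits ortho to a large group. Because the earlier step, a 1.8-fold lower number from compound 2 to compound 1 (0.24 log units; within the scatter), stayed within the scatter, a step of similar modest size is expected here too, a 1.6-fold lower number from compound 3 to compound 4 (0.19 log units; within the scatter), with wider uncertainty since the surroundings of the change differ. Compound 4 is thus estimated at 2500 nM, likely between 800 nM and 8000 nM.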

Compound 4, half-maximal inhibitory concentration: 36200 nM
Beside the measured number, compound 4's estimate is 14-fold (1.16 log units) below it, outside the stated range (above it).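

In this assay, dimethylamino in place of methyl gave a 9.3-fold higher number from compound 3 to compound 4 (0.97 log units; beyond the scatter), so on this core the swap goes with a clearly weaker inhibitor. Set beside the earlier step, the same change did not carry over from one core to the other: the same change on two cores in this assay, a 1.8-fold lower number (0.24 log units; within the scatter) from compound 2 to compound 1 and a 9.3-fold higher number (0.97 log units; beyond the scatter) from compound 3 to compound 4, 16-fold (1.21 log units) apart, beyond the scatter of two such steps This shows that the outcome of this swap on one core cannot be assumed to hold on another in this series, but with only two pairs it does not show why, since the pairs differ both in the rest of the core and in where the new group sits, which in compound 4 is ortho to a large group.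

The compounds shown leave open whether the drop belongs to dimethylamino itself or would also appear with a smaller amine, such as a plain amino group or methylamino, in the same place as in compound 4. They also leave open what dimethylamino would do on the core of compound 4 if it sat where it sits in compound 1, which would help separate the effect of its place from that of the core.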